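Swapping methylsulfanyl for a selenium-linked benzyl group

This account rests on a few compounds, and the source may have more. Where it says the series, first, only, none or still open, it means among the compounds named here.

Compound 1 `CS/C(=N\C(=O)c1ccno1)NC(=O)c1ccno1` was tested in a functional assay on HT-29 cells (Homo sapiens) for cytotoxicity, read by MTT assay, with a stated time of 72 h; a higher number here means a weaker inhibitor of growth, a lower number a stronger inhibitor of growth. In this assay compound 1 gives only a limit of the assay, > 100000 nM. Compound 2 `O=C(/N=C(/NC(=O)c1ccno1)[Se]Cc1ccccc1)c1ccno1` carries a group of 8 heavy atoms (7 carbon, 1 selenium; one six-membered aromatic ring of carbon only) in place of a group of 2 heavy atoms (1 carbon, 1 sulfur; no ring), on a carbon with a double bond to nitrogen. In this assay compound 2 gives 6820 nM, so the step is an at least 14-fold lower number from compound 1 to compound 2 (1.16 log units; beyond the scatter). Compound 3 `CS/C(=N\C(=O)c1cnc2ccccc2c1)NC(=O)c1cnc2ccccc2c1` has a different core; how the two cores differ is not broken down here. In this assay compound 3 gives only a limit of the assay, > 100000 nM. Compound 4 `O=C(/N=C(/NC(=O)c1cnc2ccccc2c1)[Se]Cc1ccccc1)c1cnc2ccccc2c1` carries a group of 8 heavy atoms (7 carbon, 1 selenium; one six-membered aromatic ring of carbon only) in place of a group of 2 heavy atoms (1 carbon, 1 sulfur; no ring), on a carbon with a double bond to nitrogen, the same change that turned compound 1 into compound 2. With two of the three values shown sitting at the limit of > 100000 nM in this assay, at which 2 of the 3 values shown sit, the expected step is an at least 5.0-fold lower number from compound 3 to compound 4 (0.69 log units; beyond the scatter). Compound 4 is therefore estimated at 20000 nM, most likely between 5000 nM and 100000 nM, though the assay may again report only a limit.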

Compound 4, concentration for 50% growth inhibition: 26100 nM
Beside the measured number, compound 4's estimate is 1.3-fold (0.12 log units) below it; measured number inside the range.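

In this assay, the swap of methylsulfanyl for the selenium-linked benzyl group carries over to the second core, with an at least 3.8-fold lower number from compound 3 to compound 4 (0.58 log units; beyond the scatter). The direction of the change therefore holds on both cores shown, but its size cannot be compared between them: the same change on two cores in this assay, an at least 14-fold lower number (1.16 log units; beyond the scatter) from compound 1 to compound 2 and an at least 3.8-fold lower number (0.58 log units; beyond the scatter) from compound 3 to compound 4; the limit leaves it open whether they differ. Compound 1 and compound 3 each stand at a limit of the assay and not at a number, so neither step has a known true size: the limit of > 100000 nM in this assay, at which 2 of the 4 values shown sit.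

Selenium and the benzyl ring enter together in this change, and the compounds shown leave open which of them matters: a benzylsulfanyl or a methylselanyl group, on a carbon with a double bond to nitrogen, would tell them apart. Also open, from the compounds shown here alone, is how an amine or a longer chain in that place would read.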